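The source may hold more compounds than are shown below. What is called first, only, known or untested is meant among the compounds shown, and "the series" means these compounds.

Compound 1 `O=C1C=COC(/C=C/c2ccccc2)C1` and compound 2 `COc1ccc(/C=C/C2CC(=O)C=CO2)cc1` share one core, and in a functional assay on MCF7 cells (Homo sapiens) for inhibition, read by sulforhodamine B assay, with a stated time of 48 h (a higher number here means a weaker inhibitor of growth, a lower number a stronger inhibitor of growth), compound 1 gives 153 uM while compound 2 gives 156 uM. The change between them is methoxy in place of hydrogen on an aromatic carbon and the step it made is a 1.0-fold higher number from compound 1 to compound 2 (0.01 log units; within the scatter), so within this pair the added group left the result unchanged.

Compound 3 `COc1ccc(/C=C/C2CC=CC(=O)O2)cc1OC` has a different core; the difference between the two cores is not broken down here. In this assay compound 3 gives 7.8 uM, the lowest of the three numbers, and its gap to both compound 1 and compound 2 lies beyond the scatter.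

Compound 4 `COc1cc(OC)c(OC)cc1/C=C/C1CC=CC(=O)O1` is not yet measured. Among the compounds with values here, it differs from compound 3 by methoxy in place of hydrogen on an aromatic carbon, which is the same kind of change as the one from compound 1 to compound 2, though not the same: in the earlier pair the entering methoxy sits para to a group of 9 heavy atoms, whereas here it sits ortho to a group of 9 heavy atoms, meta to a methoxy group and para to a methoxy group, and the core also differs. Within the data shown here, with only one earlier example, on another core, the expectation is cautious. Among the measured compounds shown here, compound 4 is expected to give about 9 uM in this assay, between 3 uM and 27 uM, because the only measured example of this kind of change is a 1.0-fold higher number from compound 1 to compound 2 (0.01 log units; within the scatter), which lies within the scatter. The expected step is a 1.2-fold higher number from compound 3 to compound 4 (0.06 log units; within the scatter).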

Compound 4, concentration for growth inhibition (reported as GI): 3.8 uM
Compound 4: the middle estimate sits 2.4-fold (0.37 log units) above what was measured; the measured number falls inside the stated range.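

In this assay, methoxy in place of hydrogen on an aromatic carbon gives a 2.1-fold lower number from compound 3 to compound 4 (0.31 log units; beyond the scatter), a modest step, while the same kind of change on the core of compound 1 gave a step within the scatter. Set side by side, the two steps do not differ by more than two such measurements can scatter, so these data give no firm sign that the core alters what this change does: the same change on two cores in this assay, a 1.0-fold higher number (0.01 log units; within the scatter) from compound 1 to compound 2 and a 2.1-fold lower number (0.31 log units; beyond the scatter) from compound 3 to compound 4, 2.1-fold (0.32 log units) apart, within the scatter of two such steps This does not show that the change carries over unaltered from one core to the other, since there are only two pairs and the entering methoxy has different surroundings in each, so the core and the place on the ring cannot be told apart.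

The compounds shown leave open whether a different group in the same place, such as a hydroxyl, an amine or a longer chain like ethoxy, would give a larger or smaller step than methoxy. From the compounds shown here alone, it also stays open whether methoxy ortho to a group of 9 heavy atoms, meta to a methoxy group and para to a methoxy group would act the same way on the core of compound 1.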